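Ring substitution on the aryl group of the shared core

The source may report more compounds than this note shows. Statements on the series, on what has been measured and on what is new or still open speak of the compounds shown alone.

Compound 2 `Cc1ccc(O)c(C2=NN(c3ccc(S(C)(=O)=O)cc3)C(=O)CC2)c1` carries a 2-hydroxy-5-methylphenyl group on the carbon with a double bond to nitrogen, and in a functional assay on the whole organism (strain Wistar) for inhibition, with Rattus norvegicus as the target, read by paw edema, with stated times of 30 min and 5 h, at a dose of 0.05 mmol/kg by the oral route (a higher number here means more inhibition at the dose given (going by the name of the read-out), a lower number less inhibition), compound 2 gives 86.8%. Among the measured compounds shown here, this is the highest of the two numbers so far; the nearest is compound 1 `CCc1ccc(C2=NN(c3ccc(S(C)(=O)=O)cc3)C(=O)CC2)cc1`, which in this assay gives 65.7%. For the measured compounds named here, the one measured step, a number 21.1 percentage points higher from compound 1 to compound 2 (beyond the scatter), came from the change of 4-ethylphenyl to 2-hydroxy-5-methylphenyl on that same carbon.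

Compound 3 `CS(=O)(=O)c1ccc(N2N=C(c3ccc(O)c(Cl)c3)CCC2=O)cc1` is the next member and differs from compound 2 as follows: 3-chloro-4-hydroxyphenyl in place of 2-hydroxy-5-methylphenyl on a carbon with a double bond to nitrogen. Going by the values given here, no measured step covers this exact exchange; the only step available, from compound 1 to compound 2, shows that changing the substitution on this aryl ring can move this assay by a modest amount, and compound 3 keeps a hydroxyl on the ring while losing the methyl and gaining a chlorine. The step of a number 11.8 percentage points lower from compound 2 to compound 3 (beyond the scatter) is therefore expected to be small to modest, more likely downward than upward, because compound 2 already gives 86.8% near the top of the range seen. For compound 3 the expected value in this assay is 75%, within 55% to 92%.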

Compound 3, a percentage reported as inhibition, in the whole organism at one dose (the size of the read-out at that dose, not a potency): 55.2%
Compound 3: middle estimate off by 19.8 percentage points, on the high side; the measured number falls inside the stated range.
By their numbers in this assay, from the lowest: compound 3; then compound 1; then compound 2.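

Working notes on the aryl position: in this assay, 3-chloro-4-hydroxyphenyl in place of 2-hydroxy-5-methylphenyl gives a number 31.6 percentage points lower from compound 2 to compound 3 (beyond the scatter), so a hydroxyl on this ring does not by itself hold the inhibition at this dose. In place of 4-ethylphenyl, the same group gives a number 10.5 percentage points lower from compound 1 to compound 3 (beyond the scatter), which places the two hydroxyl-bearing aryl groups on opposite sides of the 4-ethylphenyl compound, with compound 2 above compound 1 and compound 3 below it. The read-out at this position therefore depends on more than whether a hydroxyl is present, and nothing at hand explains the difference between these aryl groups.

The ring exchange alters the place of the hydroxyl and replaces methyl with chlorine together, so the share of the large step that belongs to each remains unresolved. Going by these compounds, how a methoxy group, an amine or a carboxylic acid on this ring would compare with the hydroxyl is also open, as is whether these differences at a single oral dose would hold across other doses.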